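Triazole substituent variation on a shared aminopyrazolopyridine-type core

A few compounds are considered here, and "the series" means these few. Any claim that something is new, unique, unknown or untested is made for them only; others in the source may bear on it.

Measured so far:
compound 1 `Nc1nn(Cc2cn(CCC(F)(F)C(F)(F)C(F)(F)C(F)(F)C(F)(F)C(F)(F)F)nn2)c2nc(-c3ccccc3)cc(C(F)(F)F)c12` — 98.2 ug/mL
compound 2 `Nc1nn(Cc2cn(-c3ccc(O)c([N+](=O)[O-])c3)nn2)c2nc(-c3ccccc3)cc(C(F)(F)F)c12` — 41.3 ug/mL

In a functional assay on U-937 cells (Homo sapiens) for cytotoxicity, read by MTT assay, with a stated time of 24 h (on this read-out lower numbers stand for stronger inhibition and higher numbers for weaker inhibition), compound 2 gives the lower of the two numbers, and compound 1 sits beyond the scatter from it. For the measured compounds named here, no step between compounds that differ in a single place is available, so the series gives no measured size for a change at the aromatic nitrogen.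

Compound 3 `Nc1nn(Cc2cn(CC(=O)Nc3ccc(F)cc3Br)nn2)c2nc(-c3ccccc3)cc(C(F)(F)F)c12` carries ((2-bromo-4-fluorophenyl)carbamoyl)methyl in place of 4-hydroxy-3-nitrophenyl on an aromatic nitrogen. Both compound 2 and compound 3 keep the shared core and the triazole, so the change is confined to that one substituent. Going by the values given here, with only two numbers and no comparable change measured, the expected step of a 1.5-fold higher number from compound 2 to compound 3 (0.16 log units; within the scatter) is small and is held within the scatter, with a slight lean toward a higher number because compound 1, the only other member, gives 98.2 ug/mL. Compound 3 is therefore estimated at 60 ug/mL, with a range from 22 ug/mL to 160 ug/mL.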

Compound 3, half-maximal inhibitory concentration: 98.3 ug/mL
For compound 3 the middle estimate is 1.6-fold (0.21 log units) below the measured one; measured number inside the range.
By their numbers in this assay, from the lowest: compound 2; then compounds 1 and 3 (each within the scatter of the next).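

In this assay, this position on an aromatic nitrogen now has its first measured step: ((2-bromo-4-fluorophenyl)carbamoyl)methyl in place of 4-hydroxy-3-nitrophenyl gives a 2.4-fold higher number from compound 2 to compound 3 (0.38 log units; beyond the scatter) and counts as modest. Compound 1 gives 98.2 ug/mL and compound 3 gives 98.3 ug/mL, two values within the scatter of each other despite the different substituents, so compound 2 stands alone with the lower number among the three. Nothing available accounts for this step.

Which part of 4-hydroxy-3-nitrophenyl goes with the lower number of compound 2 remains open: the compounds shown do not separate the hydroxy group from the nitro group. Also open, going by these compounds, is how an amine or a carboxylic acid on the same nitrogen would read in this assay.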